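The source may hold more compounds than are shown below. What is called first, only, known or untested is meant among the compounds shown, and "the series" means these compounds.

Measured so far:

Compound 1, `Fc1ccc(-c2noc3c2CCNCC3)cc1`: > 10000 nM
Compound 2, `Fc1ccc(-c2n[nH]c3c2CCNCC3)cc1`: 416 nM
Compound 3, `Clc1ccc(-c2noc3c2CCNCC3)cc1`: 360 nM

All three were tested in an assay on cells for displacement of a labelled ligand from 5-hydroxytryptamine receptor 6 (Homo sapiens), read by scintillation counting, with a stated time of 1.5 h; on this read-out lower numbers stand for stronger inhibition and higher numbers for weaker inhibition. For compound 1 the value is a limit of the assay, not a number, as the read-out reached (the limit of > 10000 nM in this assay, at which 1 of the 3 values shown sits). Compound 1 and compound 3 differ in one place only, (chloro in place of fluoro on an aromatic carbon), and this change gave an at least 27-fold lower number from compound 1 to compound 3 (1.44 log units; beyond the scatter). Compound 2 carries a different core from compound 1; how the two cores differ is not broken down here. Compound 2 and compound 3 sit close together in this assay, within the usual scatter of each other, so no order between them can be read off.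

The compound not yet measured is compound 4, `Clc1ccc(-c2n[nH]c3c2CCNCC3)cc1`. It is to compound 2 what compound 3 is to compound 1: the same change, (chloro in place of fluoro on an aromatic carbon), made on the core of compound 2 in place of the core of compound 1. Because the step of an at least 27-fold lower number from compound 1 to compound 3 (1.44 log units; beyond the scatter) starts from a limit, its full size is not known, only that it is large. Starting from the measured number of compound 2, a smaller but still clear step is expected, namely a 5.9-fold lower number from compound 2 to compound 4 (0.77 log units; beyond the scatter). On that basis compound 4 is estimated at 70 nM in this assay, with an expected range from 15 nM to 300 nM.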

Compound 4, inhibition constant: 248 nM
Estimate against measurement, compound 4: 3.5-fold (0.55 log units) below; measured number inside the range.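

Carried to the other core, chloro in place of fluoro gives a 1.7-fold lower number from compound 2 to compound 4 (0.22 log units; within the scatter) in this assay, so on this core the change cannot be told apart from the ordinary spread of repeated measurements. The effect of this swap therefore does not carry over at the same size from one core to the other, and the two steps clearly differ: the same change on two cores in this assay, an at least 27-fold lower number (1.44 log units; beyond the scatter) from compound 1 to compound 3 and a 1.7-fold lower number (0.22 log units; within the scatter) from compound 2 to compound 4, at least 16-fold (1.21 log units) apart, beyond the scatter of two such steps

What this does not show is why the two cores respond differently, or how large the first step really is, as compound 1 stands at a limit of the assay and not at a number: the limit of > 10000 nM in this assay, at which 1 of the 4 values shown sits.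

On these data alone, only fluoro and chloro appear on the aromatic ring here, so it stays open whether bromo, methoxy, a nitrile or plain hydrogen at that place would give a large step on one core and a small one on the other. As far as these compounds go, it also stays open how the same swap would read on a third core, since two cores are enough to show that a step can depend on its core but not to give a rule for predicting it.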